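Pyridine sulfonamide series: swapping the aryl for an ethylamide

The compounds below may be only part of what the source reports. "The series", "measured", "known", "first", "only" and "open" are said of these compounds alone.

Measured compounds:
compound 1 `COc1ccc(Cl)cc1S(=O)(=O)Nc1cncc(C(=O)N2CCN(C)CC2)c1`: 671 nM
compound 2 `COc1ccc(Cl)cc1S(=O)(=O)Nc1cncc(-c2cccc(C)c2)c1`: 160 nM

In an assay on isolated protein for inhibition of alkaline phosphatase, tissue-nonspecific isozyme (Homo sapiens) (on this read-out higher numbers stand for weaker inhibition and lower numbers for stronger inhibition), compound 2 gives 160 nM, the lowest of the two numbers; the nearest is compound 1 with 671 nM. Among the compounds with values here, the only step seen, a 4.2-fold lower number from compound 1 to compound 2 (0.62 log units; beyond the scatter), went from an amide to the aryl group. Compound 3 `CCNC(=O)c1cncc(NS(=O)(=O)c2cc(Cl)ccc2OC)c1` is the next compound: ethylcarbamoyl in place of 3-methylphenyl on an aromatic carbon. This change runs back toward an amide, so in this assay a rise from compound 2 is expected, somewhat smaller than the known step, and the step estimated is a 2.8-fold higher number from compound 2 to compound 3 (0.45 log units; beyond the scatter). Compound 3 is expected to give 450 nM in this assay, within 180 nM to 1200 nM.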

Compound 3, half-maximal inhibitory concentration: 193 nM
Estimate against measurement, compound 3: 2.3-fold (0.37 log units) above, and the stated range covers the measured number.
By their numbers in this assay, from the lowest: compounds 2 and 3 (each within the scatter of the next); then compound 1.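

At this position, ethylcarbamoyl, which has no ring, stands level with 3-methylphenyl in this assay, with a 1.2-fold higher number from compound 2 to compound 3 (0.08 log units; within the scatter). An aromatic ring at this carbon is therefore not needed to reach this level, and the carbonyl link alone does not set the higher number of compound 1: ethylamino in place of 4-methylpiperazin-1-yl on the carbonyl carbon gives a 3.5-fold lower number from compound 1 to compound 3 (0.54 log units; beyond the scatter). No evidence at hand bears on either step.

Still open, from the compounds shown here alone, is how a methylamide or a carboxylic acid at this carbon would compare. Going by these compounds, it is also open whether a longer chain or a piperidine on the carbonyl carbon would track compound 3 or compound 1.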